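The source may hold more compounds than are shown below. What is called first, only, known or untested is meant among the compounds shown, and "the series" means these compounds.

Of the compounds shown here, three built on one shared core have so far been tested in a functional assay on MDA-MB-231 cells (Homo sapiens) for inhibition, read by MTT assay, with a stated time of 48 h; a higher number here means a weaker inhibitor, a lower number a stronger inhibitor. Compound 1 `c1ccc2c(C3CC(c4ccncc4)=NO3)c[nH]c2c1` gives 19700 nM. Compound 2 `Cc1c(C2CC(c3ccncc3)=NO2)c2ccccc2n1Cc1ccc(Cl)cc1` gives 6660 nM in this assay. Compound 3 `COc1ccc2c(c1)c(C1CC(c3ccncc3)=NO1)cn2Cc1ccc(Cl)cc1` gives 26000 nM in this assay, the highest of the three numbers. The number of compound 1 differs from that of compound 3 by less than the usual scatter, so these two cannot be told apart. Compound 2 stands further off, its number lower than that of compound 3 by a margin beyond the scatter.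

Compound 4 `Clc1ccc(Cn2cc(C3CC(c4ccncc4)=NO3)c3ccccc32)cc1` has not yet been measured. It differs from compound 3 in a single place: hydrogen in place of methoxy on an aromatic carbon. For the measured compounds named here, no pair of measured compounds differing in only one place is available, so this step has no direct precedent in the set. Compound 2, which shares the chlorobenzyl group and lacks a methoxy, gives 6660 nM in this assay, which hints that the number may come down. For compound 4 the step is expected to be modest, toward a lower number, a 2.0-fold lower number from compound 3 to compound 4 (0.30 log units; within the scatter), and may fall within the scatter. Compound 4 is estimated at 13000 nM in this assay, with a range from 4500 nM to 38000 nM.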

Compound 4, half-maximal inhibitory concentration: 13700 nM
For compound 4 the middle estimate is 1.1-fold (0.02 log units) below the measured one, within the range that was stated.
By their numbers in this assay, from the lowest: compound 2; then compounds 4, 1 and 3 (each within the scatter of the next).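

In this assay, for the compounds shown here, the single change of hydrogen in place of methoxy on the six-membered aromatic ring gives a 1.9-fold lower number from compound 3 to compound 4 (0.28 log units; within the scatter), the first direct reading at this position, and it shows that the methoxy cannot be told from hydrogen here. The same holds for 4-chlorobenzyl in place of hydrogen on the aromatic nitrogen, which gives a 1.4-fold lower number from compound 1 to compound 4 (0.16 log units; within the scatter), so in this pair adding that group leaves no difference that can be separated from the scatter. The only one of the three changes to pass the scatter is the removal of the methyl, which gives a 2.1-fold higher number from compound 2 to compound 4 (0.31 log units; beyond the scatter) and is modest in size, so among these single changes the methyl is the one that shows up in the number.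

Nothing at hand accounts for any of these steps. Still open, as far as these compounds go, is whether an amine or a carboxylic acid on the carbon that carries the methoxy, or an ethyl group or longer chain in place of the methyl, would shift the number by more than these modest steps.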